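From Chloro to Acetyl on the Amide Aryl Ring

The source may hold more compounds than are shown below. What is called first, only, known or untested is meant among the compounds shown, and "the series" means these compounds.

Compound 1 `Cc1occc1-c1nnc(SCC(=O)Nc2ccc(F)cc2)n1Cc1ccco1` and compound 2 `Cc1occc1-c1nnc(SCC(=O)Nc2cccc(Cl)c2)n1Cc1ccco1` share a common core and differ only in the ring attached to the amide nitrogen. In a functional assay on CHO cells for antagonist activity at Orexin/Hypocretin receptor type 1 (Homo sapiens), read by FLIPR and calcium flux (a higher number here means a weaker inhibitor, a lower number a stronger inhibitor), compound 1 reaches only the limit of the assay, > 15800 nM, so no number is known for it. Compound 2 gives 2000 nM in this assay, the only true number shown. Among the compounds with values here, the one measured step, an at least 7.9-fold lower number from compound 1 to compound 2 (0.89 log units; beyond the scatter), shows that changing this ring can move the readout considerably, though because one end sits at the limit of > 15800 nM in this assay, at which 1 of the 2 values shown sits, the true size of the step is unknown.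

Compound 3 `CC(=O)c1cccc(NC(=O)CSc2nnc(-c3ccoc3C)n2Cc2ccco2)c1` carries the change (acetyl in place of chloro on an aromatic carbon). Within the data shown here, only the step from compound 1 to compound 2 bears on it, and it concerns a different swap on the same ring, so it sets no clear direction. A modest change in either direction would not be surprising, and the expectation for compound 3 is a 2.0-fold higher number from compound 2 to compound 3 (0.30 log units; within the scatter), with an estimated value of 4000 nM and a range from 1000 nM to 16000 nM.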

Compound 3, inhibition constant: 3160 nM
Compound 3: the middle estimate sits 1.3-fold (0.10 log units) above what was measured, and the stated range covers the measured number.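

In this assay, acetyl in place of chloro on this aromatic carbon gives a 1.6-fold higher number from compound 2 to compound 3 (0.20 log units; within the scatter), so the measurements cannot tell the two groups apart. This holds even though acetyl brings 3 heavy atoms where chloro brings 1, and adds a hydrogen-bond acceptor, so this place on the ring, meta to a large group, accepts both of these quite different groups with no difference beyond the scatter. The 3-acetylphenyl ring also stands clearly apart from the 4-fluorophenyl ring, with an at least 5.0-fold lower number from compound 1 to compound 3 (0.69 log units; beyond the scatter), which adds a second active ring to the comparison, but the true size of that step stays unknown because one end of it rests on a limit: the limit of > 15800 nM in this assay, at which 1 of the 3 values shown sits.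

From the compounds shown here alone, whether the same tolerance extends to other groups at this place, such as an amine, a carboxylic acid or a longer chain, remains open. Going by these compounds, compound 1 differs from compound 2 and compound 3 both in the group on the ring and in where that group sits, so which of these two differences matters also stays open.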